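The source may report more compounds than this note shows. Statements on the series, on what has been measured and on what is new or still open speak of the compounds shown alone.

Among the measured compounds shown here, in a toxicity assay on CCRF-CEM cells (Homo sapiens) for cytotoxicity (a lower number here means that less compound is tolerated, a higher number that more compound is tolerated), compound 1 `CNc1cccc2c1nc(-c1c(F)cccc1F)n2Cc1c(F)cccc1F` gives 27.2 uM and compound 2 `O=C(O)c1cccc2c1nc(-c1c(F)cccc1F)n2Cc1c(F)cccc1F` gives 23.5 uM, so compound 2 stands within the scatter of the only other measured compound. Compound 3 `O=Cc1cccc2c1nc(-c1c(F)cccc1F)n2Cc1c(F)cccc1F` differs from compound 2 at one place, with hydrogen in place of hydroxy on a carbonyl carbon, carboxy to formyl: hydrogen in place of hydroxy on a carbonyl carbon. For the measured compounds named here, the only measured step that bears on this change, a 1.2-fold lower number from compound 1 to compound 2 (0.06 log units; within the scatter), also involves the carboxy group, and on that evidence no step beyond the scatter is expected in this assay, in either direction. The estimated step is a 1.1-fold lower number from compound 2 to compound 3 (0.03 log units; within the scatter). For compound 3 the expected value is 22 uM, with an estimated range from 10 uM to 45 uM.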

Compound 3, half-maximal toxic concentration: 0.82 uM
Compound 3: middle estimate off by 27-fold (1.43 log units), on the high side; the whole stated range lies above it.
By their numbers in this assay, from the lowest: compound 3; then compounds 2 and 1 (each within the scatter of the next).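

In this assay this place on the shared core proves able to move the number far, with a 29-fold lower number from compound 2 to compound 3 (1.46 log units; beyond the scatter) for hydrogen in place of hydroxy on a carbonyl carbon and a 33-fold lower number from compound 1 to compound 3 (1.52 log units; beyond the scatter) for formyl in place of methylamino on an aromatic carbon. Carboxy and methylamino had given no such sign, so of the three groups, formyl alone stands apart. Nothing at hand explains the size of these steps. The compounds shown leave open whether a ketone or a primary alcohol at this place would stand with formyl or with carboxy. They also leave open whether the same change would give so large a step on a core with other substituents.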